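This account rests on a few compounds, and the source may have more. Where it says the series, first, only, none or still open, it means among the compounds named here.

Three compounds have numbers in an assay on isolated protein for inhibition of tyrosine-protein kinase receptor UFO (Homo sapiens), with a stated time of 1.5 h; a lower number here means a stronger inhibitor, a higher number a weaker inhibitor. Compound 1 `CC(C)Nc1ccc2c(-c3cnn(C)c3)n[nH]c2c1` gives 46600 nM, compound 2 `Cc1cnc2[nH]ccc2c1Cl` gives 20200 nM, and compound 3 `Cn1cc(-c2n[nH]c3ccc(N[C@H]4CCNC4)cc23)cn1` gives 239000 nM. Compound 3 stands at the highest number of the three; its gaps to compound 1 and to compound 2 both lie beyond the scatter, so it is the weakest inhibitor measured here.

Compound 4 `Cn1cc(-c2n[nH]c3ccc(Nc4ccccc4)cc23)cn1` differs from compound 3 in one place: phenyl in place of pyrrolidin-3-yl on a nitrogen on an aromatic ring. Among the measured compounds shown here, no measured pair shows this change, so its effect rests on the structural change alone. The expected step from compound 3 to compound 4 is a 4.8-fold lower number from compound 3 to compound 4 (0.68 log units; beyond the scatter), toward a lower number. For compound 4 the estimate in this assay is 50000 nM, with a range from 15000 nM to 200000 nM.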

Compound 4, half-maximal inhibitory concentration: 580 nM
Compound 4: the middle estimate sits 86-fold (1.94 log units) above what was measured, outside the stated range (below it).
By their numbers in this assay, from the lowest: compound 4; then compound 2; then compound 1; then compound 3.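

On the nitrogen on an aromatic ring, the group carried there strongly shapes the result in this assay: phenyl in place of pyrrolidin-3-yl gives a 410-fold lower number from compound 3 to compound 4 (2.61 log units; beyond the scatter) and counts as a large step. The change replaces a non-aromatic ring carrying a hydrogen-bond donor, a hydrogen-bond acceptor and a defined stereocentre with an all-carbon aromatic ring, and this single pair cannot separate those differences. Nothing available bears on the cause of the step. Still open, as far as these compounds go, is whether cyclohexyl or benzyl on that nitrogen gives a comparable number. Also open, from the compounds shown here alone, is how a methoxy group or a carboxylic acid on the phenyl ring would shift it.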